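The source may report more compounds than this note shows. Statements on the series, on what has been measured and on what is new or still open speak of the compounds shown alone.

Measured compounds:
compound 1 `COC(=O)C1=C(C)N=C(C)/C(=C(\O)OC)C1c1ccccc1OC` with 57.5 nM
compound 2 `COC(=O)C1=C(C)N=C(C)/C(=C(/O)OC)C1c1cccc(Cl)c1` with 15.9 nM

Two compounds of a shared core carry a measured value in a functional assay (muscle tissue) with Cavia porcellus as the target; on this read-out lower numbers stand for an effect already at smaller amounts and higher numbers for an effect only at larger amounts of compound. Compound 1 gives 57.5 nM, the highest of the two numbers; compound 2 gives 15.9 nM, the nearest number, and the gap between them is beyond the scatter of repeated measurements. Compound 3 `COC(=O)C1=C(C)N=C(C)/C(=C(\O)OC)C1c1ccc(Cl)cc1Cl` has not yet been measured in this assay. It differs from compound 1 in one place: 2,4-dichlorophenyl in place of 2-methoxyphenyl on a saturated ring carbon. Among the compounds with values here, no measured pair shows this same change, so its effect is not known directly. Because compound 2, which carries chlorine on its aryl ring, gives 15.9 nM, compound 3 is expected to give a lower number than compound 1, with a step estimated at a 3.8-fold lower number from compound 1 to compound 3 (0.58 log units; beyond the scatter). The estimate for compound 3 is 15 nM, with a range from 4 nM to 60 nM.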

Compound 3, half-maximal effective concentration: 640 nM
For compound 3 the middle estimate is 43-fold (1.63 log units) below the measured one, outside the stated range (above it).
By their numbers in this assay, from the lowest: compound 2; then compound 1; then compound 3.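

In this assay, placing 2,4-dichlorophenyl instead of 2-methoxyphenyl on the saturated ring carbon gives an 11-fold higher number from compound 1 to compound 3 (1.05 log units; beyond the scatter), a large change beyond the scatter. This position therefore responds strongly to the substituents on its aryl ring, even though both groups have the same heavy-atom count and a single six-membered aromatic ring; they differ in that 2-methoxyphenyl has one hydrogen-bond acceptor and 2,4-dichlorophenyl has none. No measurement available here explains the size of this step.

Within the data shown here, the single step cannot separate the loss of the methoxy group from the arrival of either chlorine, as the two changes occur together. On these data alone, how this position would respond to an aryl ring bearing an amine or a carboxylic acid also remains open.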